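The source may report more compounds than this note shows. Statements on the series, on what has been measured and on what is new or still open speak of the compounds shown alone.

Working notes on the series: compound 3 (`COC(=O)N[C@H](C(=O)NN(CCC[C@@](O)(Cc1ccccc1)C(=O)N[C@H]1c2ccccc2C[C@H]1O)Cc1ccc(-c2cccnc2)cc1)C(C)(C)C`) gives > 10000 nM in an ADME assay on MT4 cells (Homo sapiens) for cytotoxicity (a higher number here means that more compound is tolerated, a lower number that less compound is tolerated), as a limit of the assay and not a number. Compound 1 (`COC(=O)N[C@H](C(=O)NN(CCC[C@@](O)(Cc1ccccc1)C(=O)N[C@H]1c2ccccc2C[C@H]1O)Cc1ccc(-c2ccccn2)cc1)C(C)(C)C`) gives > 10000 nM in this assay and this too is a limit. Compound 2 (`COC(=O)N[C@H](C(=O)NN(CCC[C@@](O)(Cc1ccccc1)C(=O)N[C@H]1c2ccccc2C[C@H]1O)Cc1ccc(-c2csc(C)n2)cc1)C(C)(C)C`) gives > 10000 nM as a limit as well. Compound 3 therefore stands with the other two, and the position is the limit of > 10000 nM in this assay, at which 3 of the 3 values shown sit, with nothing to separate them.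

Compound 4 (`COC(=O)N[C@H](C(=O)NN(CCC[C@@](O)(Cc1ccccc1)C(=O)N[C@H]1c2ccccc2C[C@H]1O)Cc1ccc(-c2ccncc2)cc1)C(C)(C)C`) carries the change pyridin-4-yl in place of pyridin-3-yl on an aromatic carbon in which pyridin-4-yl takes the place of pyridin-3-yl. The closest measured change is a step that the two limits leave unreadable from compound 1 to compound 3 for a swap of pyridine attachment. The others are a step that the two limits leave unreadable from compound 1 to compound 2 and a step that the two limits leave unreadable from compound 2 to compound 3 and neither gives a size to carry over. The expected change is a step that the limit leaves unreadable from compound 3 to compound 4 with no step beyond the scatter expected in either direction. For compound 4 the estimate is 15000 nM with an expected range of 8000 nM to 40000 nM and a report of only a limit is the likeliest outcome.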

Compound 4, half-maximal cytotoxic concentration: > 10000 nM
Compound 4: a limit, no number; the forecaster's own chance of this, stated with the estimate: 85%; the middle value is on the limit's open side.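

In this assay compound 4 gives > 10000 nM, which is a limit and not a number. No step from compound 1, compound 2 or compound 3 to compound 4 can be read, and all four stand at one position: the limit of > 10000 nM in this assay, at which 4 of the 4 values shown sit.

The compounds shown leave open where any of the four would fall beyond that limit, and so whether the aryl groups on the shared core differ at all in this read-out.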